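Side-chain steps on the ring amine nitrogen

The source may hold more compounds than are shown below. What is called first, only, known or untested is meant among the compounds shown, and "the series" means these compounds.

compound 1 `Clc1ccc(CCCN2CCC(COC(c3ccccc3)c3ccccc3)CC2)cc1`: 500 nM
compound 2 `CCCCCCN1CCC(COC(c2ccccc2)c2ccccc2)CC1`: 5500 nM
compound 3 `CCCCCCCN1CCC(COC(c2ccccc2)c2ccccc2)CC1`: 500 nM

All three were read in a functional assay on cells (T-cell line, Homo sapiens) for inhibition; a lower number here means a stronger inhibitor, a higher number a weaker inhibitor. Level with compound 1, compound 3 gives 500 nM, and these two share the lowest number of the set.

The next change leads to compound 4 `c1ccc(C(OCC2CCN(CC3CCc4ccccc4C3)CC2)c2ccccc2)cc1`: 1,2,3,4-tetrahydronaphthalen-2-yl in place of hexyl on a saturated chain carbon bound to an amine nitrogen in a ring. In words, this is 1,2,3,4-tetrahydronaphthalen-2-yl in place of hexyl on a saturated chain carbon bound to an amine nitrogen in a ring.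

Within the data shown here, three measured steps bear on it. Propyl in place of 4-chlorophenyl gives an 11-fold higher number from compound 1 to compound 2 (1.04 log units; beyond the scatter), while butyl in place of 4-chlorophenyl gives no change at the digits printed from compound 1 to compound 3 (within the scatter). Methyl in place of hydrogen, six bonds along the chain from an amine nitrogen in a ring, gives an 11-fold lower number from compound 2 to compound 3 (1.04 log units; beyond the scatter). A small change can therefore move the number a long way, in this assay at least. Compound 4 carries a six-membered aromatic ring in its entering group, and compound 1, with 4-chlorophenyl, gives 500 nM. Among the measured compounds shown here, no measured compound carries the entering group itself, so the range stays wide, with more room towards higher numbers.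

The expected step is a 1.2-fold higher number from compound 3 to compound 4 (0.08 log units; within the scatter), so no change beyond the scatter is foreseen. For compound 4 the estimate is 600 nM, with an expected range of 150 nM to 3000 nM.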

Compound 4, half-maximal inhibitory concentration: 5600 nM
Estimate against measurement, compound 4: 9.3-fold (0.97 log units) below; the whole stated range lies below it.
By their numbers in this assay, from the lowest: compounds 1 and 3 (each within the scatter of the next); then compounds 2 and 4 (each within the scatter of the next).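

In this assay the 1,2,3,4-tetrahydronaphthalen-2-yl group on a saturated chain carbon bound to an amine nitrogen in a ring does not hold the level reached with hexyl (an 11-fold higher number from compound 3 to compound 4 (1.05 log units; beyond the scatter)), and its result stays within the scatter of the one with pentyl (a 1.0-fold higher number from compound 2 to compound 4 (0.01 log units; within the scatter)). A six-membered aromatic ring in the entering group therefore does not by itself match 2-(4-chlorophenyl)ethyl (an 11-fold higher number from compound 1 to compound 4 (1.05 log units; beyond the scatter)), and the step from hexyl shows that a larger all-carbon group, 10 heavy atoms against 6, does not by itself preserve the lower number either. No measurement available here explains these steps.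

Open, as far as these compounds go, is whether an unsubstituted 2-phenylethyl group, a 2-(4-fluorophenyl)ethyl group or a longer chain such as heptyl would stay level with compound 1 and compound 3 or move towards compound 2 and compound 4. Also open, from the compounds shown here alone, is how a hydroxyl group or a second amine on the chain would change the number, so the tolerance of this position to anything other than carbon, apart from the chlorine of compound 1, remains undefined.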